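A Stilbene Arm in Place of a Hydroxymethyl Group

A few compounds are considered here, and "the series" means these few. Any claim that something is new, unique, unknown or untested is made for them only; others in the source may bear on it.

Compound 1 `C=C[C@@](C)(/C=C/c1ccc(O)cc1)CCC=O` and compound 2 `C=C[C@@](C)(/C=C/c1ccc(O)c(CO)c1)CCC=C(C)C` share the same core. In an ADME assay on BJ cells (Homo sapiens) for cytotoxicity, with a stated time of 72 h (on this read-out higher numbers stand for an effect only at larger amounts of compound and lower numbers for an effect already at smaller amounts), compound 1 gives > 36600 nM, which is a limit of the assay rather than a number. Compound 2 likewise gives > 36600 nM in this assay, again a limit and not a number. Compound 2 therefore stands at the limit of > 36600 nM in this assay, at which 2 of the 2 values shown sit, with no measured number that sets it apart from compound 1. Compound 3 `C=C[C@@](C)(/C=C/c1ccc(O)c(/C=C/c2ccc(F)cc2)c1)CCC=C(C)C` differs from compound 2 in one place: 2-(4-fluorophenyl)ethenyl in place of hydroxymethyl on an aromatic carbon. Going by the values given here, no step between two measured compounds is available, so there is no measured size to lean on. The expectation is a modest step toward an effect at smaller amounts, estimated as an at least 1.4-fold lower number from compound 2 to compound 3 (0.16 log units; that floor lies within the scatter), though it may well stay within the scatter, and a fresh limit remains quite possible. For compound 3 the estimate in this assay is 25000 nM, with a range from 6000 nM to 36600 nM.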

Compound 3, half-maximal effective concentration: > 36600 nM
Compound 3: only a limit was reported; the forecaster's own chance of this, stated with the estimate: 50%; middle value at least 1.4-fold (0.16 log units) away from the limit.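

Compound 3 also gives only a limit of the assay rather than a number, so no step can be read between compound 2 and compound 3: the limit of > 36600 nM in this assay, at which 3 of the 3 values shown sit.

The compounds shown leave open what amount of any of them would reach a half-maximal effect in this assay, and whether 2-(4-fluorophenyl)ethenyl in place of hydroxymethyl alters that amount at all.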